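A few compounds are considered here, and "the series" means these few. Any claim that something is new, unique, unknown or untested is made for them only; others in the source may bear on it.

Measured so far:
compound 1 `CCn1c(C(C)NS(=O)(=O)c2ccc(Cl)cc2)nc2cccnc21` — 94 mL.min-1.g-1
compound 2 `CCn1c([C@@H](C)NS(=O)(=O)c2ccccc2)nc2ccc(C(F)(F)F)cc21` — 14 mL.min-1.g-1

In an ADME assay (liver) for metabolic stability, with Liver microsome (Homo sapiens) as the target, read by LC-MS, using microsomes and NADPH, with a stated time of 5 min, at 37 degrees C (a lower number here means slower removal, a higher number faster removal of the compound), compound 2 stands lowest of the two numbers; compound 1 gives the higher figure, and the gap between them lies beyond the scatter. Compound 3 `CCCn1ncc(S(=O)(=O)N[C@H](C)c2nc3ccc(C(F)(F)F)cc3n2CC)c1C` carries one change relative to compound 2: 5-methyl-1-propyl-1H-pyrazol-4-yl in place of phenyl on a sulfonyl sulfur. For the measured compounds named here, no measured step covers this change, so the direction is open. A small rise in this assay is expected, near the edge of the scatter, giving a 1.6-fold higher number from compound 2 to compound 3 (0.20 log units; within the scatter) from compound 2 to compound 3. Compound 3 is therefore estimated at 22 mL.min-1.g-1, with a range of 9 mL.min-1.g-1 to 50 mL.min-1.g-1.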

Compound 3, intrinsic clearance in microsomes: > 100 mL.min-1.g-1
Compound 3 gave a limit, no number (the forecaster's own chance of this, stated with the estimate: 5%); middle value at least 4.5-fold (0.65 log units) from the limit.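

In this assay the group on the sulfonyl sulfur alone moves the read-out beyond the scatter, something compounds 1 and 2, which differ in more than one place, could not show: 5-methyl-1-propyl-1H-pyrazol-4-yl in place of phenyl gives an at least 7.1-fold higher number from compound 2 to compound 3 (0.85 log units; beyond the scatter). From the compounds shown here alone, the figure for compound 3 is a limit and not a number, so the full size of this step stays unknown: the limit of > 100 mL.min-1.g-1 in this assay, at which 1 of the 3 values shown sits.

Whether the pyrazole ring or its propyl chain accounts for the rise remains open. A shorter chain such as methyl on that ring, or a pyridine ring on the sulfonyl sulfur, would bear on this.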